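Indolyl to Fluorophenyl: Expected Potency of Compound 4

A few compounds are considered here, and "the series" means these few. Any claim that something is new, unique, unknown or untested is made for them only; others in the source may bear on it.

Compound 1 `COc1cc(-c2ccnc3cc(-c4ccc(C)cc4)nn23)cc(OC)c1OC`, compound 2 `COc1cc(-c2ccnc3cc(-c4ccc5cc[nH]c5c4)nn23)cc(OC)c1OC` and compound 3 `COc1ccc(-c2cc3nccc(-c4cc(OC)c(OC)c(OC)c4)n3n2)cc1F` share one core and differ only in the aryl group attached to it. In a functional assay on HCT-116 cells (Homo sapiens) for inhibition, read by CCK-8 assay, with a stated time of 48 h (a lower number here means a stronger inhibitor, a higher number a weaker inhibitor), compound 1 gives 48 nM, compound 2 gives 187 nM and compound 3 gives 2840 nM, so compound 2 stands second highest of the three, with a 3.9-fold higher number from compound 1 to compound 2 (0.59 log units; beyond the scatter) on one side and a 15-fold higher number from compound 2 to compound 3 (1.18 log units; beyond the scatter) on the other. Compound 4 `COc1cc(-c2ccnc3cc(-c4ccc(F)cc4)nn23)cc(OC)c1OC` carries 4-fluorophenyl in place of 1H-indol-6-yl on an aromatic carbon. The step of a 59-fold higher number from compound 1 to compound 3 (1.77 log units; beyond the scatter) shows that a substituted phenyl can lose much, yet 4-fluorophenyl resembles 4-methylphenyl more closely than 3-fluoro-4-methoxyphenyl does, so a modest downward step, a 2.1-fold lower number from compound 2 to compound 4 (0.32 log units; beyond the scatter), is expected. Compound 4 is estimated at 90 nM, within 30 nM to 300 nM.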

Compound 4, half-maximal inhibitory concentration: 5030 nM
Estimate against measurement, compound 4: 56-fold (1.75 log units) below, and the stated range ends below it.
By their numbers in this assay, from the lowest: compound 1; then compound 2; then compounds 3 and 4 (each within the scatter of the next).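

Replacing methyl with fluoro on the aryl group of compound 1 is the largest step in the series (a 100-fold higher number from compound 1 to compound 4 (2.02 log units; beyond the scatter)), so this position responds sharply to a single substituent change. Moving from 1H-indol-6-yl to 4-fluorophenyl also costs much (a 27-fold higher number from compound 2 to compound 4 (1.43 log units; beyond the scatter)), while compound 4 is not separated from its 3-fluoro-4-methoxyphenyl analogue (a 1.8-fold higher number from compound 3 to compound 4 (0.25 log units; within the scatter)). Nothing available explains this loss of potency. From the compounds shown here alone, whether 4-chlorophenyl, 4-ethylphenyl or 4-aminophenyl would stand nearer compound 1 or compound 4 stays open.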